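The source may hold more compounds than are shown below. What is called first, only, known or untested is meant among the compounds shown, and "the series" means these compounds.

Of the compounds shown here, three have been measured in a physicochemical assay for solubility, read by spectrophotometry, in phosphate buffer, with a stated time of 2 h, at pH 7.4; a lower number here means a less soluble compound, a higher number a more soluble compound. Compound 1, `COc1cccc(CN2C(=O)CN(C(=O)c3cc4cc(OC)ccc4o3)C[C@@H]2CCc2ccccc2)c1`, gives 4900 nM. Compound 2, `COc1ccc2[nH]c(C(=O)N3CC(=O)N(Cc4ccccc4)[C@@H](COc4ccccc4)C3)cc2c1`, gives 12200 nM. Compound 3, `COc1cccc(CN2C(=O)CN(C(=O)c3cc4cc(OC)ccc4[nH]3)C[C@@H]2Cc2ccccn2)c1`, gives 57900 nM. Among these three numbers compound 2 stands second highest: the nearest number is that of compound 1, which lies lower by more than the usual scatter, and the furthest is that of compound 3, which lies higher by more than the scatter.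

Compound 4, `COc1ccc2[nH]c(C(=O)N3CC(=O)N(Cc4ccccc4)[C@@H](CN4C(=O)c5ccccc5C4=O)C3)cc2c1`, has not yet been measured in this assay. It differs from compound 2 in one place: a group of 11 heavy atoms (8 carbon, 1 nitrogen, 2 oxygen; one five-membered non-aromatic ring with 1 hetero atom, one six-membered aromatic ring of carbon only) in place of a group of 7 heavy atoms (6 carbon, 1 oxygen; one six-membered aromatic ring of carbon only), on a saturated chain carbon bound to a saturated ring carbon. Within the data shown here, no pair of measured compounds differs in just this way, so the size of this step cannot be read from measured numbers and has to be estimated.

The expectation is that the step from compound 2 to compound 4 in this assay is downward and beyond the scatter, a 2.4-fold lower number from compound 2 to compound 4 (0.39 log units; beyond the scatter). On that basis compound 4 is expected to give about 5000 nM in this assay, with a likely range from 1500 nM to 15000 nM.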

Compound 4, solubility: > 100000 nM
Compound 4: no number, only a limit (the forecaster's own chance of this, stated with the estimate: 5%); middle value at least 20-fold (1.30 log units) from the limit.
By their numbers in this assay, from the lowest: compound 1; then compound 2; then compound 3. At a limit, above all of these: compound 4.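

In this assay, among these compounds, this is the first step that can be read at the saturated chain carbon bound to a saturated ring carbon, and putting the larger group with the five-membered non-aromatic ring in place of phenoxy gives an at least 8.1-fold higher number from compound 2 to compound 4 (0.91 log units; beyond the scatter). Compound 4 gives > 100000 nM, which is a limit of the assay and not a number, so the step has a lower bound but no known full size. Even so, the step shows that a group of 11 heavy atoms in place of phenoxy at this carbon does not push the number down, and it puts compound 4 at the top of the compounds shown: the limit of > 100000 nM in this assay, at which 1 of the 4 values shown sits.

As far as these compounds go, a single step cannot separate the effect of the five-membered ring in the entering group from that of its two double bonds outside aromatic rings, so which part of the group goes with the higher number stays open. From the compounds shown here alone, how an amine, a carboxylic acid or a longer chain on this same carbon would read in this assay also stays open.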